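Nitro in place of acetyl on the shared core

The compounds below may be only part of what the source reports. "The series", "measured", "known", "first", "only" and "open" are said of these compounds alone.

Working notes on the series. Compound 1 `COc1ccc2c(c1)c(C=O)cn2Cc1cn([C@@H]2O[C@H](COC(C)=O)[C@@H](OC(C)=O)[C@H](OC(C)=O)[C@H]2OC(C)=O)nn1` carries a formyl group on the shared core. In an ADME assay on NIH3T3 cells (Homo sapiens) for cytotoxicity, read by sulforhodamine B assay, with a stated time of 48 h (a lower number here means a stronger inhibitor, a higher number a weaker inhibitor), compound 1 reaches only a limit of the assay, > 200000 nM. Compound 2 `COc1ccc2c(c1)c(/C=N/O)cn2Cc1cn([C@@H]2O[C@H](COC(C)=O)[C@@H](OC(C)=O)[C@H](OC(C)=O)[C@H]2OC(C)=O)nn1` carries the oxime in its place, and in this assay compound 2 gives 26200 nM; this is an at least 7.6-fold lower number from compound 1 to compound 2 (0.88 log units; beyond the scatter). Compound 3 `CC(=O)OC[C@H]1O[C@@H](n2cc(Cn3cc(C(C)=O)c4ccccc43)nn2)[C@H](OC(C)=O)[C@@H](OC(C)=O)[C@@H]1OC(C)=O` bears an acetyl group on the shared core. In this assay compound 3 again reaches only a limit, > 200000 nM. Compound 3 thus stands at the limit of > 200000 nM in this assay, at which 2 of the 3 values shown sit, and no number is known for it.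

Compound 4 `CC(=O)OC[C@H]1O[C@@H](n2cc(Cn3cc([N+](=O)[O-])c4ccccc43)nn2)[C@H](OC(C)=O)[C@@H](OC(C)=O)[C@@H]1OC(C)=O` differs from compound 3 by nitro in place of acetyl on an aromatic carbon. Within the data shown here, the only measured step concerns the formyl and oxime groups at another position of the shared core, so no measured step follows the acetyl-to-nitro exchange directly. For compound 4 in this assay the expected step is a number no higher from compound 3 to compound 4 (the limit leaves the size open), none beyond the scatter. Compound 4 is therefore estimated at 200000 nM, with a range from 60000 nM to 400000 nM, and most likely again reported only as a limit.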

Compound 4, half-maximal inhibitory concentration: 20500 nM
Estimate against measurement, compound 4: 9.8-fold (0.99 log units) above; the whole stated range lies above it.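

In this assay, the exchange of acetyl for nitro at this aromatic carbon of the five-membered ring is enough on its own to bring a compound off the limit: an at least 9.7-fold lower number from compound 3 to compound 4 (0.98 log units; beyond the scatter). This shows that the group at this carbon can decide whether a number is reached at all, not only with the formyl-to-oxime step but also with a second, different exchange, here with the rest of compound 3 unchanged. The step remains a bound, not an exact size, and the values that are not numbers sit at one limit: the limit of > 200000 nM in this assay, at which 2 of the 4 values shown sit.

From the compounds shown here alone, whether an amine, a nitrile or a carboxylic acid at this carbon would also give a number remains open. The compounds shown also leave open whether nitro has a similar effect on the core of compound 1, and they do not tell why the exchange changes the read-out.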